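Working notes on half-life in the series

A few compounds are considered here, and "the series" means these few. Any claim that something is new, unique, unknown or untested is made for them only; others in the source may bear on it.

Compound 1 `C=C1CC(CO)OC1=O` gives 13 h in a physicochemical assay for pharmacokinetics; on this read-out lower numbers stand for a shorter-lived compound and higher numbers for a longer-lived compound.
Compound 2 `C=C1C(=O)OC(CO)C1O` reaches only a limit of this assay, < 7 h.
Compound 3 `C=C(CO)C(=O)OC` likewise sits at a limit of this assay, > 60 h.

For the measured compounds named here, compound 2 thus stands at the limit of < 7 h in this assay, at which 1 of the 3 values shown sits; the one step that touches it, an at least 1.8-fold lower number from compound 1 to compound 2 (0.26 log units; that floor lies within the scatter), ends at that limit and so gives only a lower bound on its size. The next compound, compound 4 `C=C1C(=O)OCC1O`, differs from compound 2 by hydrogen in place of hydroxymethyl on a saturated ring carbon. Going by the values given here, no measured step removes a hydroxymethyl, and compound 3 differs from compound 2 in more than one place, so its value can only be set beside that of compound 2 without a step. Compound 4 is therefore expected to stay near compound 2, with no step beyond the scatter: a step that the limit leaves unreadable from compound 2 to compound 4. The estimate for compound 4 is 5 h, range 2 h to 12 h.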

Compound 4, half-life: < 7 h
Compound 4 gave a limit, no number; the forecaster's own chance of this, stated with the estimate: 45%; the middle value lies beyond the limit too.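

Compound 2 and compound 4 both sit at a limit in this assay, and the step between them cannot be read: the limit of < 7 h in this assay, at which 2 of the 4 values shown sit.

The compounds shown leave open whether hydrogen in place of hydroxymethyl on a saturated ring carbon changes the half-life at all.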